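The compounds below may be only part of what the source reports. "The series", "measured", "known", "first", "only" and "open" are said of these compounds alone.

Measured in a functional assay on KB cells (Homo sapiens) for antiproliferative activity, read by sulforhodamine B assay, with a stated time of 3 days; on this read-out higher numbers stand for an effect only at larger amounts of compound and lower numbers for an effect already at smaller amounts:
- Compound 1 `CCOc1ccc(-c2cc(=O)c3c(o2)C(CC)(CC)C(=O)C(CC)=C3O)cc1`: > 52.4 uM, a limit
- Compound 2 `CCC1=C(O)c2c(oc(-c3ccc(COC)cc3)cc2=O)C(CC)(CC)C1=O`: > 52.4 uM, a limit
- Compound 3 `CCC1=C(O)c2c(oc(-c3ccccc3OC)cc2=O)C(CC)(CC)C1=O`: 40.8 uM

Going by the values given here, compound 3 holds the only true number in this small set. The other two compounds share one result: the limit of > 52.4 uM in this assay, at which 2 of the 3 values shown sit.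

Compound 4 `CCC1=C(O)c2c(oc(-c3ccc(C)cc3C)cc2=O)C(CC)(CC)C1=O` has 2,4-dimethylphenyl in place of 2-methoxyphenyl on an aromatic carbon, next to the ring oxygen: 2,4-dimethylphenyl in place of 2-methoxyphenyl on an aromatic carbon.

Two measured steps change the group at this same place: an at least 1.2-fold lower number from compound 1 to compound 3 (0.10 log units; that floor lies within the scatter) and an at least 1.2-fold lower number from compound 2 to compound 3 (0.10 log units; that floor lies within the scatter). Both are only minimum sizes, and those minimums lie within the scatter. The third, a step that the two limits leave unreadable from compound 1 to compound 2, cannot be read at all. None of the three brings in the 2,4-dimethylphenyl group, so the measured steps give no reason to expect a real shift in either direction in this assay.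

The estimated change is a 1.1-fold higher number from compound 3 to compound 4 (0.04 log units; within the scatter), which is expected to stay within the scatter. The assay may also report only a limit. For compound 4 the expected value is 45 uM, with an estimated range of 20 uM to 85 uM.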

Compound 4, concentration for half-maximal effect: 41.2 uM
Compound 4: middle estimate off by 1.1-fold (0.04 log units), on the high side; the range from low to high includes it.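

In this assay, going by these compounds alone, there is a 1.0-fold higher number from compound 3 to compound 4 (0.00 log units; within the scatter), the first step at this position with a true number at both ends. The oxygen of 2-methoxyphenyl and its hydrogen-bond acceptor can therefore give way to the all-carbon 2,4-dimethylphenyl group, and the two values cannot be told apart. Against the other two compounds the steps are only minimum sizes, an at least 1.2-fold lower number from compound 2 to compound 4 (0.10 log units; that floor lies within the scatter) and an at least 1.2-fold lower number from compound 1 to compound 4 (0.10 log units; that floor lies within the scatter), because those compounds stop at a limit: the limit of > 52.4 uM in this assay, at which 2 of the 4 values shown sit.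

Going by these compounds, all four compounds carry a substituted phenyl ring at this position, so it remains open whether an amine or a carboxylic acid on that ring, or a longer alkyl chain in its place, would give a clearly lower number. On these data alone, the separate contribution of each methyl group in compound 4 also remains open.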